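Swapping an aromatic group for a (diethylamino)methyl group

The compounds below may be only part of what the source reports. "The series", "measured", "known", "first", "only" and "open" are said of these compounds alone.

Compound 1 `CC1=NN(C(=O)c2ccc([N+](=O)[O-])cc2)C(c2ccccc2O)C1`: 50000 nM
Compound 2 `CC1=NN(C(=O)c2ccc(C)cc2)C(c2ccccc2O)C1`: 26300 nM
Compound 3 `CC1=NN(C(=O)c2ccc(C)cc2)C(c2cc(Br)ccc2O)C1`: 21000 nM

In a functional assay on MGC-803 cells (Homo sapiens) for cytotoxicity, read by MTT assay, with a stated time of 48 h (on this read-out lower numbers stand for stronger inhibition and higher numbers for weaker inhibition), compound 2 gives 26300 nM, the middle of the three numbers, and its steps to both other compounds lie within the scatter. Compound 4 `CCN(CC)CC(=O)N1N=C(C)CC1c1ccccc1O` has not yet been measured. It differs from compound 2 by (diethylamino)methyl in place of 4-methylphenyl on a carbonyl carbon.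

Among the compounds with values here, two measured steps bear on this change, though only loosely. One is a 1.9-fold lower number from compound 1 to compound 2 (0.28 log units; within the scatter), with methyl in place of nitro on an aromatic carbon. The other is a 1.3-fold lower number from compound 2 to compound 3 (0.10 log units; within the scatter), with bromo in place of hydrogen on an aromatic carbon. Within the data shown here, both are small edits, whereas compound 4 loses the whole 4-methylphenyl, and no measured compound carries (diethylamino)methyl. The data therefore point in no firm direction, and no step beyond the scatter is expected in this assay, with wide uncertainty. The estimated step is a 1.1-fold higher number from compound 2 to compound 4 (0.06 log units; within the scatter). For compound 4 the estimated value is 30000 nM, with an expected range from 10000 nM to 90000 nM.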

Compound 4, half-maximal inhibitory concentration: 39800 nM
The estimate for compound 4 lay 1.3-fold (0.12 log units) below the measured number; low and high end bracket the measured number.
By their numbers in this assay, from the lowest: compounds 3, 2, 4 and 1 (each within the scatter of the next, the first and the last beyond it).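

Compound 4 gives up the whole 4-methylphenyl on the carbonyl carbon, and with it a six-membered aromatic ring, for a (diethylamino)methyl with no ring, and in this assay the result is a 1.5-fold higher number from compound 2 to compound 4 (0.18 log units; within the scatter) even though this edit is far larger than the earlier ones. Within the data shown here, the earlier steps changed only single substituents, so this is the first sign that, for this pair, the group on the carbonyl carbon can be replaced outright with no change beyond the scatter. Nothing measured here accounts for this result.

The compounds shown leave open whether the nitrogen of the new group matters, which a plain pentyl chain at the same place would test. They also leave open how a carboxylic acid or a piperidine ring there would read.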